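Fluoro to chloro on the sulfonamide aryl of compound 2

A few compounds are considered here, and "the series" means these few. Any claim that something is new, unique, unknown or untested is made for them only; others in the source may bear on it.

Measured compounds:
- compound 1, `COc1ccc(S(=O)(=O)Nc2ccc(-c3nc4ccccc4o3)cc2)cc1`: in an assay on cells for inhibition of HSP60/HSP10 (Homo sapiens), with a stated time of 60 min (a higher number here means a weaker inhibitor, a lower number a stronger inhibitor), compound 1 gives only the limit > 100000 nM.
- compound 2, `O=S(=O)(Nc1ccc2oc(-c3ccccc3)nc2c1)c1cccc(F)c1`: in this assay compound 2 gives only the limit > 100000 nM.
- compound 3, `O=S(=O)(Nc1ccc(-c2nc3cc(NS(=O)(=O)c4cccc(O)c4)ccc3o2)cc1)c1cccc(O)c1`: in this assay compound 3 gives 17000 nM.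

For the measured compounds named here, compound 2 therefore sits at the limit of > 100000 nM in this assay, at which 2 of the 3 values shown sit, where it shares its place with compound 1; only compound 3 gives a number at all, and no step between measured compounds is available.

Compound 4, `O=S(=O)(Nc1ccc2oc(-c3ccccc3)nc2c1)c1cccc(Cl)c1`, differs from compound 2 by chloro in place of fluoro on an aromatic carbon. Going by the values given here, with no measured step to lean on and compound 2 at a limit, no shift beyond the scatter is expected, a step that the limit leaves unreadable from compound 2 to compound 4. Compound 4 is estimated at 150000 nM, within 50000 nM to 500000 nM, most likely again reported only as a limit.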

Compound 4, half-maximal inhibitory concentration: > 100000 nM
Compound 4: no number, only a limit; the forecaster's own chance of this, stated with the estimate: 80%; the middle value does not contradict the limit.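

For the compounds shown here, compound 2 and compound 4 both give only a limit in this assay, so no step between them can be read. Left open is whether chloro in place of fluoro changes inhibition at all.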